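The compounds below may be only part of what the source reports. "The series", "measured", "known", "first", "only" and "open" are said of these compounds alone.

Of the compounds shown here, three have been tested in a functional assay on U-937 cells (Homo sapiens) for cytotoxicity, read by WST assay, with a stated time of 72 h; a lower number here means a stronger inhibitor, a higher number a weaker inhibitor. Compound 1 `COc1cc2c(Nc3nc4ccc(C(=O)Nc5c(C)cccc5C)cc4s3)ncnc2cc1OCCCN1CCCCC1` gives 14700 nM in this assay. Compound 2 `COc1cc2c(Nc3nc4ccc(C(=O)Nc5c(C)cccc5C)cc4s3)ncnc2cc1OCCCN1CCCCC1C` carries methyl in place of hydrogen on a saturated ring carbon, here next to the ring nitrogen, and in this assay compound 2 gives 10800 nM; the step is a 1.4-fold lower number from compound 1 to compound 2 (0.13 log units; within the scatter). Compound 3 `COc1cc2c(Nc3nc4ccc(C(=O)Nc5c(C)cccc5Cl)cc4s3)ncnc2cc1OCCCN1CCCCC1` differs from compound 1 by chloro in place of methyl on an aromatic carbon, and in this assay compound 3 gives 8600 nM, a step of a 1.7-fold lower number from compound 1 to compound 3 (0.23 log units; within the scatter). Compound 4 `COc1cc2c(Nc3nc4ccc(C(=O)Nc5c(C)cccc5Cl)cc4s3)ncnc2cc1OCCCN1CCC(C)CC1` is not yet measured. It adds to compound 3 the same kind of change seen between compound 1 and compound 2, (methyl in place of hydrogen on a saturated ring carbon), but the methyl now sits three ring bonds from the ring nitrogen rather than next to it. Because the earlier step of a 1.4-fold lower number from compound 1 to compound 2 (0.13 log units; within the scatter) stayed within the scatter, a similarly small step is expected, a 1.2-fold lower number from compound 3 to compound 4 (0.09 log units; within the scatter). Compound 4 is estimated at 7000 nM, between 3000 nM and 17000 nM.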

Compound 4, half-maximal inhibitory concentration: 9200 nM
Beside the measured number, compound 4's estimate is 1.3-fold (0.12 log units) below it; low and high end bracket the measured number.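

In this assay, adding the methyl to the saturated ring of compound 3 gives a 1.1-fold higher number from compound 3 to compound 4 (0.03 log units; within the scatter). Set beside the earlier step, the two cores show no difference in how they take this change: the same change on two cores in this assay, a 1.4-fold lower number (0.13 log units; within the scatter) from compound 1 to compound 2 and a 1.1-fold higher number (0.03 log units; within the scatter) from compound 3 to compound 4, 1.5-fold (0.16 log units) apart, within the scatter of two such steps. This does not prove that the change carries over exactly: in compound 4 the methyl stands three ring bonds from the ring nitrogen, in compound 2 it stands elsewhere on the ring, and steps this small could hide a real difference between cores.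

Still open, as far as these compounds go, is how a larger group on this ring carbon, such as an ethyl or a hydroxyl, would read. Also open, from the compounds shown here alone, is whether a morpholine in place of the piperidine would read differently.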